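The compounds below may be only part of what the source reports. "The series", "measured", "known", "first", "only" and "open" are said of these compounds alone.

Measured compounds:
compound 1, `CC(C(=O)N1CCN(c2ccccc2Cl)CC1)N1C(=O)CCC1=O`: in a functional assay on the whole organism (strain Swiss) with Mus musculus as the target, in the maximal electroshock model, with a stated time of 0.5 h, at a dose of 300 mg/kg by the intraperitoneal route (on this read-out lower numbers stand for a weaker effect and higher numbers for a stronger effect at the one dose given), compound 1 gives 0%.
compound 2, `CC(C(=O)N1CCN(c2cccc(C(F)(F)F)c2)CC1)N1C(=O)CCC1=O`: in this assay compound 2 gives 100%.

Compound 2 holds the higher of the two numbers recorded so far. For the measured compounds named here, its nearest neighbour, compound 1, stands far lower, a gap well beyond the scatter; the two differ in the aryl substituent and its placement, and no single-point step joins them, so the pair shows only that the series spans the whole range of the read-out at this dose.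

Compound 3, `Cc1cccc(N2CCN(C(=O)C(C)N3C(=O)CCC3=O)CC2)c1`, is the next compound to be measured. It differs from compound 2 as follows: methyl in place of trifluoromethyl on an aromatic carbon. Going by the values given here, no measured pair carries this same change, so the size of the step in this assay is open. Because compound 2 gives 100%, the higher of the two recorded numbers, the step is expected to go down or to stay within the scatter; a moderate decrease is expected, with a wide spread.

For compound 3 the expected value is 67%, with a range from 0% to 100%. The step this estimate means, a number 33 percentage points lower from compound 2 to compound 3 (beyond the scatter), is an expected decline that may yet fall within the scatter.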

Compound 3, a percentage reported as activity, at one dose (the size of the read-out at that dose, not a potency): 50%
Beside the measured number, compound 3's estimate is 17 percentage points above it; measured number inside the range.
By their numbers in this assay, from the lowest: compound 1; then compound 3; then compound 2.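

In this assay, the change from trifluoromethyl to methyl on an aromatic carbon, meta to a large group, gives a number 50 percentage points lower from compound 2 to compound 3 (beyond the scatter), so this position responds to the group it carries, and methyl keeps part of the read-out rather than losing it all. The change of 3-methylphenyl for 2-chlorophenyl on the ring amine nitrogen gives a number 50 percentage points higher from compound 1 to compound 3 (beyond the scatter), which places compound 3 between the other two compounds; this step alters both the substituent and its place on the aryl ring, so it does not separate the two. No measurement of any property of these compounds bears on either step, and the reason for their size stays unexplained.

The compounds shown leave open how a methoxy group, a chlorine atom or a nitrile on this same aromatic carbon would stand in this assay, and whether the difference between 2-chlorophenyl and 3-methylphenyl follows the chlorine or its place on the ring. On these data alone, all of these readings come from a single dose and time, so how the compounds rank in potency also remains open.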